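Saturating the Chain of Compound 1

The source may report more compounds than this note shows. Statements on the series, on what has been measured and on what is new or still open speak of the compounds shown alone.

Going by the values given here, only two compounds have numbers so far in an ADME assay on HaCaT cells (Homo sapiens) for cytotoxicity, read by sulforhodamine B assay, with a stated time of 48 h (a lower number here means that less compound is tolerated, a higher number that more compound is tolerated), and the question is what one small edit does to the first of them. Compound 1 (`CCCCC/C=C\C/C=C\CCCCCCCC(=O)N1CCCCC1`) gives 4.2 ug/mL and stands lowest of the two. Compound 2 (`CCCCCC[C@@H](O)C/C=C\CCCCCCCC(=O)N1CCOCC1`) gives 41.3 ug/mL and that gap lies beyond the usual scatter of repeated measurements, so compound 1 is the less tolerated of the pair.

Among the compounds with values here, compound 3 (`CCCCCCCC/C=C\CCCCCCCC(=O)N1CCCCC1`) keeps the core of compound 1 and carries heptyl in place of hept-1-en-1-yl on a saturated chain carbon bound to a double-bonded chain carbon as its only change. Within the data shown here, no measured pair shows this change, so the expectation rests on the structural edit alone. An edit this small is expected to move the number in this assay only slightly, perhaps upward, and probably not beyond the scatter. The estimated step is a 1.4-fold higher number from compound 1 to compound 3 (0.15 log units; within the scatter) and a larger shift cannot be ruled out. Compound 3 is estimated at 6 ug/mL with 2.5 ug/mL to 18 ug/mL as its expected range.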

Compound 3, concentration lethal to 50% of the cells: 7.7 ug/mL
Compound 3: the middle estimate sits 1.3-fold (0.11 log units) below what was measured; low and high end bracket the measured number.
By their numbers in this assay, from the lowest: compounds 1 and 3 (each within the scatter of the next); then compound 2.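

Going by these compounds alone, replacing hept-1-en-1-yl with heptyl on a saturated chain carbon bound to a double-bonded chain carbon gives a 1.8-fold higher number from compound 1 to compound 3 (0.26 log units; within the scatter) in this assay and provides the first direct reading of a single change at this position. Because that step lies within the usual scatter, these two compounds cannot be told apart here, so losing this one double bond outside aromatic rings has no clear effect on the number, even though the chain keeps the same count of heavy atoms. Compound 2 differs from compound 3 in more than one place, so it cannot be used to judge this edit, and nothing measured alongside these numbers bears on why the edit changes so little.

Going by these compounds, the result covers only the exchange of one seven-carbon chain for another, so it remains open whether a longer chain such as decyl or a shorter one such as propyl in place of heptyl on this saturated chain carbon would move the number beyond the scatter. On these data alone, it is equally open whether a chain carrying an amine or a carboxylic acid would be tolerated differently in this assay from the plain heptyl of compound 3.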